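Nitro on the fused ring: carry-over to compound 2

The source may report more compounds than this note shows. Statements on the series, on what has been measured and on what is new or still open speak of the compounds shown alone.

Compound 1 `CCn1cc(-c2nc3ccccc3o2)c(=O)c2cc(F)c(N3CCN(C)CC3)cc21` and compound 3 `CCn1cc(-c2nc3ccc([N+](=O)[O-])cc3o2)c(=O)c2cc(F)c(N3CCN(C)CC3)cc21` share a core; compound 2 `CCn1cc(-c2nc3ccccc3o2)c(=O)c2cc(F)c(N3CCNCC3)nc21` has a different core, and the difference between the two cores is not broken down here. In a functional assay on Bel-7402 cells (Homo sapiens) for cytotoxicity, read by MTT assay, with a stated time of 48 h (on this read-out higher numbers stand for weaker inhibition and lower numbers for stronger inhibition), compound 1 gives 2000 nM, compound 3 gives 50200 nM, and compound 2 gives 16800 nM. The change from compound 1 to compound 3 is nitro in place of hydrogen on an aromatic carbon, and it made a step of a 25-fold higher number from compound 1 to compound 3 (1.40 log units; beyond the scatter).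

Compound 4 `CCn1cc(-c2nc3ccc([N+](=O)[O-])cc3o2)c(=O)c2cc(F)c(N3CCNCC3)nc21` is not yet measured. It differs from compound 2 by nitro in place of hydrogen on an aromatic carbon, the same change as from compound 1 to compound 3, made on the other core; the change occurs twice among the compounds shown. Going by the values given here, the only measured instance of the change is the one from compound 1 to compound 3, so the expectation rests on a single pair, and on compound 2 starting from a higher number than compound 1.

The step from compound 2 to compound 4 in this assay is expected to be a 15-fold higher number from compound 2 to compound 4 (1.17 log units; beyond the scatter), somewhat tempered against the measured step because of a 25-fold higher number from compound 1 to compound 3 (1.40 log units; beyond the scatter) resting on one pair. Compound 4 is estimated at 250000 nM, between 80000 nM and 800000 nM.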

Compound 4, half-maximal inhibitory concentration: 3000 nM
The estimate for compound 4 lay 83-fold (1.92 log units) above the measured number; the measured number lies below the stated range.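

In this assay, nitro in place of hydrogen on an aromatic carbon gave a 5.6-fold lower number from compound 2 to compound 4 (0.75 log units; beyond the scatter), so on the core of compound 2 the number moved in the opposite direction to the one seen on the core of compound 1. The same change therefore gave two clearly different steps on the two cores: the same change on two cores in this assay, a 25-fold higher number (1.40 log units; beyond the scatter) from compound 1 to compound 3 and a 5.6-fold lower number (0.75 log units; beyond the scatter) from compound 2 to compound 4, 140-fold (2.15 log units) apart, beyond the scatter of two such steps. This shows that, for these two pairs, a step measured on one core did not carry over to the other, but with a single pair per core it does not show which feature of the cores goes with the reversal, and the difference between them is not broken down here.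

Going by these compounds, it remains open whether other groups on the same aromatic carbon, such as an amino group, a chlorine atom or a carboxylic acid, would also part ways between the two cores. On these data alone, whether the reversal for nitro extends to further cores or to other cell lines is also open.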